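This account rests on a few compounds, and the source may have more. Where it says the series, first, only, none or still open, it means among the compounds named here.

Working notes on the series, values from a functional assay on 1A9 cells (Homo sapiens) for cytotoxicity; on this read-out higher numbers stand for an effect only at larger amounts of compound and lower numbers for an effect already at smaller amounts:
- compound 1 `COC1=C(C)C(=O)/C(=C(O)/C=C/c2cccc(OC)c2)C(=O)C1(C)C` gives 2.9 ug/mL
- compound 2 `COC1=C(C)C(=O)/C(=C(O)/C=C/c2cccc3ccccc23)C(=O)C1(C)C` gives "not determined" (no result reported)
- compound 3 `CCCC1=C(OC)C(CCC)(CCC)C(=O)/C(=C(O)\C=C\c2ccccc2)C1=O` gives 1.5 ug/mL

Only two of these entries carry a number, as compound 2 has no result. Compound 3 at 1.5 ug/mL and compound 1 at 2.9 ug/mL lie within the usual scatter of each other, so no order can be read between them. Going by the values given here, compound 3 therefore stands level with the only other number available in this assay.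

The next compound to be measured is compound 4 `CCCC1=C(OC)C(CCC)(CCC)C(=O)/C(=C(O)\C=C\c2ccc(Br)cc2)C1=O`. It departs from compound 3 by one change, (bromo in place of hydrogen on an aromatic carbon), which turns phenyl into 4-bromophenyl, para to a large group. Among the compounds with values here, no pair of measured compounds shows what a bromo does here, and no measured step exists to carry over. The expectation therefore rests on compound 3 at 1.5 ug/mL, and no shift beyond the scatter is expected, in either direction. The estimated change is a 1.2-fold lower number from compound 3 to compound 4 (0.06 log units; within the scatter), which stays within the scatter. For compound 4 the expected value is 1.3 ug/mL, with an estimated range of 0.5 ug/mL to 3.2 ug/mL.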

Compound 4, concentration for half-maximal effect: 0.9 ug/mL
Estimate against measurement, compound 4: 1.4-fold (0.16 log units) above; measured number inside the range.
By their numbers in this assay, from the lowest: compounds 4, 3 and 1 (each within the scatter of the next, the first and the last beyond it).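

In this assay, the change from phenyl to 4-bromophenyl reads as a 1.7-fold lower number from compound 3 to compound 4 (0.22 log units; within the scatter), so compound 3 and compound 4 stand level. Going by these compounds alone, this is the first step that speaks to this position, as the earlier compounds offered no pair differing in one place. It shows that a bromo can take the place of hydrogen on this aromatic carbon, para to a large group, on the core of compound 3 without a difference that can be told from the scatter, although a single step sets no trend, and nothing at hand gives a reason for this result.

Going by these compounds, it remains open whether this level reading is particular to bromo or also holds at the same carbon for other groups, such as fluoro, an amine or a carboxylic acid. On these data alone, it is also open whether the bromo would read the same on the core of compound 1, which carries methyl groups where compound 3 carries propyl chains.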